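Replacing a dichlorinated aryl group with plain phenyl

The compounds below may be only part of what the source reports. "The series", "measured", "known", "first", "only" and "open" are said of these compounds alone.

Compound 1 `COc1cc(C=C2C(=O)N(c3ccc(Cl)cc3)N(c3ccc(Cl)cc3)C2=O)ccc1O` gives 7100 nM in a functional assay on ECa-109 cells (Homo sapiens) for cytotoxicity, read by MTT assay, with a stated time of 72 h; on this read-out higher numbers stand for weaker inhibition and lower numbers for stronger inhibition.
Compound 2 `O=C1C(=Cc2ccc(Cl)cc2Cl)C(=O)N(c2ccc(Cl)cc2)N1c1ccc(Cl)cc1` gives 60200 nM in this assay.

Among the two measured compounds, compound 2 stands at the highest number; its nearest neighbour is compound 1, and the step of an 8.5-fold higher number from compound 1 to compound 2 (0.93 log units; beyond the scatter) is the only measured step in this set. The unmeasured compound 3 `O=C1C(=Cc2ccccc2)C(=O)N(c2ccc(Cl)cc2)N1c1ccc(Cl)cc1` differs from compound 2 in one place: phenyl in place of 2,4-dichlorophenyl on a double-bonded chain carbon bound to a double-bonded ring carbon.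

Among the measured compounds shown here, only one measured step bears on this change, and only indirectly: in the step from compound 1 to compound 2 the aryl group on the double-bonded chain carbon was exchanged and the number rose beyond the scatter, so this position is sensitive to the aryl group carried there. For the measured compounds named here, no measured pair shows what removing both chlorines from the 2,4-dichlorophenyl does. With compound 2 at the highest number, the step for compound 3 is expected to fall, and a step of a 2.0-fold lower number from compound 2 to compound 3 (0.30 log units; within the scatter) is estimated. Compound 3 is therefore expected to give about 30000 nM, within a range from 10000 nM to 90000 nM.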

Compound 3, half-maximal inhibitory concentration: 32700 nM
Estimate against measurement, compound 3: 1.1-fold (0.04 log units) below; measured number inside the range.
By their numbers in this assay, from the lowest: compound 1; then compounds 3 and 2 (each within the scatter of the next).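

In this assay, removing both chlorines from the 2,4-dichlorophenyl group gave a 1.8-fold lower number from compound 2 to compound 3 (0.27 log units; within the scatter), so at this place the two chlorines make no difference that can be told from the scatter. Setting phenyl in place of 4-hydroxy-3-methoxyphenyl gave a 4.6-fold higher number from compound 1 to compound 3 (0.66 log units; beyond the scatter), which shows that the plain ring, like the 2,4-dichlorophenyl group, stands apart from the 4-hydroxy-3-methoxyphenyl group of compound 1, while compound 2 and compound 3 cannot be separated from each other. No measurement among these compounds offers an explanation for either step.

Going by these compounds, whether the hydroxy group, the methoxy group or both together set compound 1 apart remains open, as does how an amine or a carboxylic acid on the aryl ring at this place would read in this assay. On these data alone, all three compounds also share the rest of the core, so it remains open whether these steps would hold if the groups elsewhere on that core were different.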